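Acylation of the free amine in compound 1

A few compounds are considered here, and "the series" means these few. Any claim that something is new, unique, unknown or untested is made for them only; others in the source may bear on it.

Of the three compounds measured in a functional assay on SiHa cells (Homo sapiens) for cytotoxicity, read by MTT assay, with a stated time of 48 h (on this read-out higher numbers stand for weaker inhibition and lower numbers for stronger inhibition), compound 1 `CCCCCCCCCCCCCCNC(=O)[C@@H](N)[C@@H](C)O` gives 11000 nM; compound 3 `CCCCCCCCCCCCNC(=O)[C@@H](NC(=O)c1cc2ccccc2o1)[C@@H](C)O` gives 12900 nM, within the scatter of that, and compound 2 `CCCCCCCCCCCCCCCCCCNC(=O)[C@@H](N)[C@@H](C)O` gives 39500 nM, beyond it. Among the compounds with values here, the only single-point step measured, a 3.6-fold higher number from compound 1 to compound 2 (0.56 log units; beyond the scatter), concerns the chain and not the amine. The change to compound 4 `CCCCCCCCCCCCCCNC(=O)[C@@H](NC(=O)c1cccs1)[C@@H](C)O` is (thiophen-2-yl)carbonyl in place of hydrogen on an amine nitrogen. Within the data shown here, no measured step isolates this change; compound 3 differs from compound 1 in both acyl group and chain length, and the two values lie within the scatter of each other. Compound 4 is therefore expected to show no step beyond the scatter, a 1.2-fold higher number from compound 1 to compound 4 (0.07 log units; within the scatter). The estimate for compound 4 is 13000 nM, with a range of 5000 nM to 35000 nM.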

Compound 4, half-maximal inhibitory concentration: 63000 nM
Beside the measured number, compound 4's estimate is 4.8-fold (0.69 log units) below it; the measured number lies above the stated range.
By their numbers in this assay, from the lowest: compounds 1 and 3 (each within the scatter of the next); then compounds 2 and 4 (each within the scatter of the next).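

Placing (thiophen-2-yl)carbonyl on the amine nitrogen gives the first reading that isolates this position: in this assay the change produces a 5.7-fold higher number from compound 1 to compound 4 (0.76 log units; beyond the scatter). The free amine of compound 1 therefore cannot be acylated with this group without a loss of inhibition in these cells. No evidence on the cause of this step is available.

The compounds shown leave open whether the step follows from acylation of this nitrogen as such or from the (thiophen-2-yl)carbonyl group itself. An acetyl group on the same nitrogen, with the chain of compound 1, would separate these two readings.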